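Swapping a hydroxyl position on a shared core

The source may hold more compounds than are shown below. What is called first, only, known or untested is meant among the compounds shown, and "the series" means these compounds.

Of the compounds shown here, two of one family have been measured in an assay on isolated protein for inhibition of DNA topoisomerase 1 (Homo sapiens), with a stated time of 30 min, tested at 20 uM; a higher number here means a stronger effect of the compound at the concentration tested, a lower number a weaker effect. Compound 1, `Oc1ccc(-c2cc(-c3ccco3)cc(-c3cccc(O)c3)n2)cc1`, gives 1.5% in this assay. Compound 2, `Oc1cccc(-c2cc(-c3cccnc3)cc(-c3cccc(O)c3)n2)c1`, gives 1.9% in this assay, which is the higher of the two numbers, though its distance to compound 1 lies within the usual scatter, so the two are not told apart. Compound 3, `Oc1ccc(-c2cc(-c3cccnc3)cc(-c3cccc(O)c3)n2)cc1`, has not been measured. The change from compound 2 to compound 3 is 4-hydroxyphenyl in place of 3-hydroxyphenyl on an aromatic carbon. Compound 1 already carries a 4-hydroxyphenyl group and gives a number no different from that of compound 2 beyond the scatter, so no step beyond the scatter is expected in either direction here. The expected step from compound 2 to compound 3 is a number 0.1 percentage points higher from compound 2 to compound 3 (within the scatter). For compound 3 in this assay the estimate is 2%, between -6% and 10%.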

Compound 3, a percentage reported as inhibition, at one concentration (the size of the read-out at that concentration, not a potency): 2.8%
Beside the measured number, compound 3's estimate is 0.8 percentage points below it, within the range that was stated.
By their numbers in this assay, from the lowest: compounds 1, 2 and 3 (each within the scatter of the next).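

In this assay, among these compounds, 4-hydroxyphenyl in place of 3-hydroxyphenyl on the aromatic carbon next to the ring nitrogen gives a number 0.9 percentage points higher from compound 2 to compound 3 (within the scatter) and so offers the first direct comparison of these two groups at this place: with pyridin-3-yl held fixed, the two hydroxyphenyl groups cannot be told apart. Compound 3 also allows a second one-place comparison, as pyridin-3-yl in place of furan-2-yl gives a number 1.3 percentage points higher from compound 1 to compound 3 (within the scatter) and leaves those two groups equally unresolved. No supporting data bear on why these numbers fall as they do.

As far as these compounds go, it remains open whether a group of a different kind at this place, such as an amine or a carboxylic acid, would give a number beyond the scatter. The compounds shown also cannot tell whether a methoxy group in place of the hydroxyl would change the read-out.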